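This account rests on a few compounds, and the source may have more. Where it says the series, first, only, none or still open, it means among the compounds named here.

Measured compounds:
- compound 1 `Cn1sc2cc(OCc3cccc(-c4ccc(Cl)c(C(=O)O)c4)c3)ccc2c1=O`: 640 nM
- compound 2 `CN(C)C(=O)c1cc(-c2cccc(COc3ccc4c(=O)n(C5CCCC5)sc4c3)c2)ccc1Cl`: 980 nM

In an assay on HEK293 cells for positive allosteric modulation of metabotropic glutamate receptor 2 (Rattus norvegicus), read by thallium flux (a higher number here means that more compound is needed for the effect, a lower number that less compound is needed), compound 1 gives 640 nM, the lower of the two numbers, but the gap to compound 2 at 980 nM lies within the usual scatter, so the two cannot be told apart. Compound 3 `O=C(O)c1cc(-c2cccc(COc3ccc4c(=O)n(C5CCC5)sc4c3)c2)ccc1Cl` differs from compound 1 by cyclobutyl in place of methyl on an aromatic nitrogen. For the measured compounds named here, no measured pair shows this change on its own. Compound 2, which carries a cyclopentyl on the same nitrogen together with a different substituent on the terminal ring, gives a number close to that of compound 1, so a move toward a larger ring on this nitrogen has so far produced no step beyond the scatter. For compound 3 a small downward shift at most is expected, a 1.4-fold lower number from compound 1 to compound 3 (0.15 log units; within the scatter), and the estimate is 450 nM with a range from 150 nM to 1400 nM.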

Compound 3, half-maximal effective concentration: 580 nM
Compound 3: the middle estimate sits 1.3-fold (0.11 log units) below what was measured; the measured number falls inside the stated range.
By their numbers in this assay, from the lowest: compounds 3, 1 and 2 (each within the scatter of the next).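

In this assay, the exchange of methyl for cyclobutyl on the aromatic nitrogen, next to the ring sulfur, can now be read on its own: it gives a 1.1-fold lower number from compound 1 to compound 3 (0.04 log units; within the scatter) with the rest of the structure unchanged. This position therefore takes a four-membered non-aromatic ring of carbon only in place of methyl with no change that can be told from the scatter, something compound 2 could not show, as it differs from compound 1 in more than one place. Nothing measured here bears on the reason for this result.

As far as these compounds go, it remains open how cyclopentyl on this nitrogen reads with the carboxylic acid kept in place, and what the exchange of that acid for the dimethylamide does on its own. The compounds shown also say nothing about an open chain such as isopropyl, or a ring carrying an amine, at this position.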